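A Methyl Group Added Where Inhibition Is Already Lost

The source may report more compounds than this note shows. Statements on the series, on what has been measured and on what is new or still open speak of the compounds shown alone.

Compound 1 `CC1=NN(c2ccccc2)C(=O)C12C=CC(=O)C=C2c1ccccc1` gives 27400 nM in a functional assay on MDA-MB-231 cells (Homo sapiens) for antiproliferative activity, read by CCK-8 assay, with a stated time of 72 h; on this read-out higher numbers stand for weaker inhibition and lower numbers for stronger inhibition.
Compound 2 `CC1=NN(c2ccc(C)cc2)C(=O)C12C=CC(=O)C=C2c1ccccc1` gives 46600 nM in this assay.
Compound 3 `CC1=NN(c2ccc(Cl)cc2)C(=O)C12C=CC(=O)C=C2c1ccccc1` gives only a limit of the measurement, > 100000 nM in this assay.

All three share one core. Compound 3 differs from compound 1 by chloro in place of hydrogen on an aromatic carbon, and the steps of an at least 3.6-fold higher number from compound 1 to compound 3 (0.56 log units; beyond the scatter) and an at least 2.1-fold higher number from compound 2 to compound 3 (0.33 log units; beyond the scatter) both end at the limit of > 100000 nM in this assay, at which 1 of the 3 values shown sits.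

Compound 4 `CC1=NN(c2ccc(Cl)cc2)C(=O)C12C=CC(=O)C=C2c1ccc(C)cc1` is not yet measured. It differs from compound 3 by methyl in place of hydrogen on an aromatic carbon. The same change, (methyl in place of hydrogen on an aromatic carbon), gave the step of a 1.7-fold higher number from compound 1 to compound 2 (0.23 log units; within the scatter), which stays within the scatter. The step from compound 3 to compound 4 is expected to be equally small, a step that the limit leaves unreadable from compound 3 to compound 4. This rests on compound 3 already sitting at the limit of > 100000 nM in this assay, at which 1 of the 3 values shown sits. Compound 4 is expected to give about 150000 nM, again most likely only a limit, somewhere from 60000 nM to 400000 nM.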

Compound 4, half-maximal inhibitory concentration: 14300 nM
The estimate for compound 4 lay 10-fold (1.02 log units) above the measured number, and the stated range ends above it.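

Methyl in place of hydrogen on an aromatic carbon gives an at least 6.9-fold lower number from compound 3 to compound 4 (0.84 log units; beyond the scatter) in this assay. Set beside the earlier step, the same change does not carry over with one size or direction from one core to the other: the same change on two cores in this assay, a 1.7-fold higher number (0.23 log units; within the scatter) from compound 1 to compound 2 and an at least 6.9-fold lower number (0.84 log units; beyond the scatter) from compound 3 to compound 4, at least 11-fold (1.07 log units) apart, beyond the scatter of two such steps
Compound 3 gives only a limit, > 100000 nM, so this step has no exact size, and with the methyl on different phenyl rings in compound 2 and compound 4, the two steps do not show why they part.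

On these data alone, what stays open is how the same methyl change behaves on the phenyl ring altered in compound 4 when the chloro is absent. Also open, as far as these compounds go, is whether an ethyl, methoxy or amine group there would follow the methyl of compound 4.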